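The source may hold more compounds than are shown below. What is called first, only, known or untested is meant among the compounds shown, and "the series" means these compounds.

In a physicochemical assay for lipophilicity, using the shake flask method, in phosphate buffer, measured as octanol-water partition, with a stated time of 24 h, at pH 7.4 (on this read-out higher numbers stand for higher lipophilicity and lower numbers for lower lipophilicity), compound 1 `Cc1nn(-c2ccccc2F)c2c1CCS(=O)(=O)O2` gives 1.86, compound 2 `Cc1nn(-c2ccccc2F)c2c1C(c1ccc(F)cc1)CS(=O)(=O)O2` gives 2.13 and compound 3 `O=S1(=O)CC(c2ccc(F)cc2)c2c(C3CC3)nn(-c3ccccc3F)c2O1` gives 1.76. Compound 2 therefore cannot be told apart from compound 1, while compound 3 falls below it beyond the scatter. Compound 4 `Cc1cc(C2CS(=O)(=O)Oc3c2c(C)nn3-c2ccccc2F)ccc1Br` is still unmeasured and differs from compound 2 in one place: 4-bromo-3-methylphenyl in place of 4-fluorophenyl on a saturated ring carbon. The nearest evidence comes from that same carbon, where 4-fluorophenyl in place of hydrogen gave a number 0.27 log units higher from compound 1 to compound 2 (within the scatter). Cyclopropyl in place of methyl on an aromatic carbon gave a number 0.37 log units lower from compound 2 to compound 3 (beyond the scatter), but that change lies elsewhere. For the measured compounds named here, no measured step swaps one substituted phenyl for another, so the expected change, a number 0.47 log units higher from compound 2 to compound 4 (beyond the scatter), is only loosely supported. For compound 4 the estimated value is 2.6, with an expected range from 2.1 to 3.1.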

Compound 4, partition coefficient: 2.26
Estimate against measurement, compound 4: 0.34 log units above; low and high end bracket the measured number.
By their numbers in this assay, from the lowest: compounds 3, 1, 2 and 4 (each within the scatter of the next, the first and the last beyond it).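

On the saturated ring carbon, this assay gives a number 0.13 log units higher from compound 2 to compound 4 (within the scatter) when 4-bromo-3-methylphenyl replaces 4-fluorophenyl, so this swap of one substituted phenyl for another cannot be told from no change. Measured against hydrogen on that carbon, the same group gives a number 0.40 log units higher from compound 1 to compound 4 (beyond the scatter) and clears the scatter, which 4-fluorophenyl did not do. No measured evidence explains either step. Going by these compounds, an amine or a carboxylic acid on that carbon remains open, since only phenyl groups and hydrogen appear there. On these data alone, whether either phenyl group behaves the same with cyclopropyl in place of methyl also remains open.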